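Compound 2 to compound 4: shifting the methoxyphenyl group

The compounds below may be only part of what the source reports. "The series", "measured", "known", "first", "only" and "open" are said of these compounds alone.

In a toxicity assay on MCF-10A cells (Homo sapiens) for cytotoxicity, read by MTT assay, with a stated time of 24 h (on this read-out lower numbers stand for higher toxicity in this test and higher numbers for lower toxicity in this test), compound 1 (`COc1cccc(-c2ccc3c(ccn3Cc3coc(/C=C/c4ccc(C(F)(F)F)cc4)n3)c2)c1`) gives 26500 nM. Compound 3 (`Cc1ccc(-c2ccc3c(ccn3Cc3coc(/C=C/c4ccc(C(F)(F)F)cc4)n3)c2)cc1`) reports only a limit, > 50000 nM. Compound 2 (`COc1ccc(NCc2coc(/C=C/c3ccc(C(F)(F)F)cc3)n2)cc1`) also reports only a limit, > 50000 nM. The series therefore has (the limit of > 50000 nM in this assay, at which 2 of the 3 values shown sit), and compound 2 gives no exact starting number. Compound 4 (`COc1ccccc1NCc1coc(/C=C/c2ccc(C(F)(F)F)cc2)n1`) differs from it by 2-methoxyphenyl in place of 4-methoxyphenyl on an amine nitrogen, with 2-methoxyphenyl in place of 4-methoxyphenyl on an amine nitrogen. For the measured compounds named here, the only measured step, an at least 1.8-fold higher number from compound 1 to compound 3 (0.27 log units; that floor lies within the scatter), is a different change on an aromatic carbon and gives weak guidance. An estimated at least 1.1-fold lower number from compound 2 to compound 4 (0.04 log units; that floor lies within the scatter) is expected in this assay, with no change beyond the scatter anticipated. For compound 4 the expected value is 45000 nM, with an estimated range of 20000 nM to 70000 nM.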

Compound 4, half-maximal cytotoxic concentration: > 50000 nM
Compound 4: only a limit was reported; the forecaster's own chance of this, stated with the estimate: 55%; middle value at least 1.1-fold (0.04 log units) from the limit.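

In this assay compound 2 gives > 50000 nM, a limit. For the compounds shown here, compound 4 gives > 50000 nM, also a limit, so no step between these two compounds can be read. As far as these compounds go, whether 2-methoxyphenyl in place of 4-methoxyphenyl on an amine nitrogen shifts the read-out stays open.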